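The source may report more compounds than this note shows. Statements on the series, on what has been measured and on what is new or still open speak of the compounds shown alone.

Among the measured compounds shown here, compound 1 `O=C(C/C=C/c1cccc(Cl)c1)Nc1nc2ccccc2c(=O)s1` is one of two compounds measured so far in an assay on membranes from brain for displacement of a labelled ligand from adenosine receptor A1 (Rattus norvegicus), read by scintillation counting, with a stated time of 90 min; on this read-out lower numbers stand for stronger inhibition and higher numbers for weaker inhibition. In this assay compound 1 gives 11.4 nM. Compound 2 `O=C(CCCc1ccccc1)Nc1nc2ccc(Br)cc2c(=O)s1` shares the same core but carries a different chain and a bromo group on it. In this assay compound 2 reaches only > 10000 nM, which is a limit of the assay and not a number. So compound 1 holds the only number shown, while the other value is a limit, namely (the limit of > 10000 nM in this assay, at which 1 of the 2 values shown sits); the two are so far apart and so differently built that no single step can be read between them.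

Compound 3 `O=C(C/C=C/c1ccc(Cl)c(Cl)c1)Nc1nc2ccccc2c(=O)s1` has not yet been measured. It differs from compound 1 in one place: chloro in place of hydrogen on an aromatic carbon, which, read one bond further out, means 3-chlorophenyl becomes 3,4-dichlorophenyl. For the measured compounds named here, no measured pair shows this change, so the expectation rests on compound 1 alone, at 11.4 nM. For compound 3 a step of a 1.4-fold lower number from compound 1 to compound 3 (0.15 log units; within the scatter) is expected, toward stronger binding but no larger than the usual scatter. Compound 3 is thus expected to give about 8 nM, within a range from 3 nM to 25 nM.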

Compound 3, inhibition constant: >= 1500 nM
Compound 3: only a limit was reported (the forecaster's own chance of this, stated with the estimate: 2%); at least 180-fold (2.27 log units) between middle value and limit.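

In this assay, turning 3-chlorophenyl into 3,4-dichlorophenyl gives an at least 130-fold higher number from compound 1 to compound 3 (2.11 log units; beyond the scatter), so one chloro in place of hydrogen on this aromatic carbon, ortho to a chloro group and para to a large group, is enough to weaken binding far beyond the scatter. This is the first pair shown that differs in one place only, and it reveals that this carbon of the ring is highly sensitive to the change, even though the change adds just one heavy atom and no ring, hydrogen-bond donor, hydrogen-bond acceptor or charge. The figure for compound 3 is a limit of the assay and not a number: the limit of >= 1500 nM in this assay, at which 1 of the 3 values shown sits.

Chloro is the only group shown on this carbon, so it remains open whether a smaller fluoro, or a methoxy group, on the same carbon would weaken binding to a similar degree. The compounds shown also do not tell why this single added chloro has so large an effect, or whether it would have the same effect on a different chain or core.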